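The source may report more compounds than this note shows. Statements on the series, on what has been measured and on what is new or still open speak of the compounds shown alone.

In a functional assay on MCF7 cells (Homo sapiens) for antiproliferative activity, with a stated time of 96 h (on this read-out higher numbers stand for weaker inhibition and lower numbers for stronger inhibition), compound 1 `Cc1cc(=O)oc2cc(OCC(=O)c3ccc(C(C)(C)C)cc3)ccc12` gives 20700 nM. Compound 2 `CC(C)(C)c1ccc(C(=O)COc2ccc3c(C(F)(F)F)cc(=O)oc3c2)cc1` in the same assay is recorded as "not active" (no number reported), with no number given.

In this assay compound 1 gives 20700 nM, a weak result. Compound 2 stands without a number in this assay: it was recorded only as "not active" (no number reported), so its place among the numbers cannot be fixed. Compound 3 `N#Cc1ccc(C(=O)COc2ccc3c(C(F)(F)F)cc(=O)oc3c2)cc1` differs from compound 2 in one place: cyano in place of tert-butyl on an aromatic carbon. Within the data shown here, no measured step shows what this change does here, so no size or direction beyond the scatter can be claimed, and compound 3 may well remain inactive. Compound 3 is expected to be weak, around 25000 nM, in the range 5000 nM to 100000 nM.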

Compound 3, half-maximal inhibitory concentration: "not active" (no number reported)
For compound 3 the study gives words and no number; the estimate stays without a comparison.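

In this assay compound 2 and compound 3 are both recorded only as not active, so no step can be read between them. No evidence shown bears on this result. The compounds shown leave open whether cyano in place of tert-butyl changes activity at all.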